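Chloro for methyl on a chromone dithiocarbamate

The source may report more compounds than this note shows. Statements on the series, on what has been measured and on what is new or still open speak of the compounds shown alone.

The shared core of these compounds is a fused bicyclic ring bearing a carbonyl and a side chain ending in a dithiocarbamate. Among the measured compounds shown here, compound 1 `Cc1ccc2c(=O)c(CSC(=S)N(C(C)C)C(C)C)coc2c1` carries a methyl on the aromatic ring and is the only compound with a numeric result: in a functional assay on HeLa cells (Homo sapiens) for antiproliferative activity, read by MTT assay, with a stated time of 72 h (on this read-out lower numbers stand for stronger inhibition and higher numbers for weaker inhibition), compound 1 gives 1400 nM. Compound 2 `CCOC(=O)c1cc(=O)c2cc(CSC(=S)N(C(C)C)C(C)C)ccc2o1` gives in this assay only a limit, > 25000 nM. Compound 3 `O=c1c(CSC(=S)N2CCN(C(c3ccc(F)cc3)c3ccc(F)cc3)CC2)coc2ccccc12` likewise gives only a limit, > 25000 nM. So compound 1 stands as the single measured number, with the other two values sitting at the limit of > 25000 nM in this assay, at which 2 of the 3 values shown sit.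

Compound 4 `CC(C)N(C(=S)SCc1coc2cc(Cl)ccc2c1=O)C(C)C` differs from compound 1 in one place: chloro in place of methyl on an aromatic carbon. For the measured compounds named here, no step between two measured compounds exists here to show what such an exchange does, so the expectation rests on compound 1 alone. Because compound 1 gives 1400 nM, compound 4 is expected to stay close to it, with a step of a 1.1-fold higher number from compound 1 to compound 4 (0.03 log units; within the scatter) that may not exceed the usual scatter. Compound 4 is therefore estimated at 1500 nM, within a range from 500 nM to 5000 nM.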

Compound 4, half-maximal inhibitory concentration: > 25000 nM
Compound 4: a limit, no number; the forecaster's own chance of this, stated with the estimate: 10%; at least 16-fold (1.22 log units) between middle value and limit.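

The earlier compounds shown here could not show whether this aromatic carbon tolerates change, and here it does not: in this assay, chloro in place of methyl gives an at least 17-fold higher number from compound 1 to compound 4 (1.25 log units; beyond the scatter). Each group counts as 1 heavy atom, so even an exchange this small at this place, with the rest of compound 1 unchanged, separates a measurable value from none. Compound 4 gives only a limit, so the step marks the least possible size of the loss, and compound 4 joins the compounds that give no number: the limit of > 25000 nM in this assay, at which 3 of the 4 values shown sit.

The compounds shown leave open whether methyl is specially favoured here or chloro specially disfavoured, and no cause for the loss can be read from them. A plain hydrogen, fluoro, methoxy or an ethyl group at this carbon could help settle that question.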